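Replacing the ethenyl chain of compound 3

The source may hold more compounds than are shown below. What is called first, only, known or untested is meant among the compounds shown, and "the series" means these compounds.

Measured in a functional assay with Oryctolagus cuniculus as the target; a lower number here means a stronger inhibitor, a higher number a weaker inhibitor:
- compound 1 `COc1ccc(-c2nc(/N=C(\N)N(C)C)sc2-c2ccc(OC)cc2)cc1`: 37 nM
- compound 2 `COc1ccc(-c2nc(CNC(=O)c3cccnc3)sc2-c2ccc(OC)cc2)cc1`: 25 nM
- compound 3 `CCOC(=O)/C(C#N)=C/c1nc(-c2ccc(OC)cc2)c(-c2ccc(OC)cc2)s1`: < 10 nM

Compound 3 stands at < 10 nM, which is a limit and not a number. Its steps to the other two are an at least 3.7-fold lower number from compound 1 to compound 3 (0.56 log units; beyond the scatter) and an at least 2.5-fold lower number from compound 2 to compound 3 (0.39 log units; beyond the scatter), both beyond the scatter, so it is the strongest inhibitor of the three in this assay. The remaining step, a 1.5-fold lower number from compound 1 to compound 2 (0.17 log units; within the scatter), lies within the scatter, even though the two groups differ widely.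

Compound 4 `COc1ccc(-c2nc(CCC(=O)O)sc2-c2ccc(OC)cc2)cc1` keeps the shared core and carries 2-carboxyethyl in place of 2-cyano-2-(ethoxycarbonyl)ethenyl (2-carboxyethyl in place of 2-cyano-2-(ethoxycarbonyl)ethenyl on an aromatic carbon). The three measured steps all concern this same aromatic carbon. Compound 4 is expected to land near the two measured numbers, since compound 1 gives 37 nM and compound 2 gives 25 nM. The expected change is a modest move to a higher number, an at least 4.0-fold higher number from compound 3 to compound 4 (0.60 log units; beyond the scatter). Compound 4 is estimated at 40 nM, with an expected range from 10 nM to 200 nM.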

Compound 4, half-maximal inhibitory concentration: < 100 nM
Compound 4 was reported as a limit; the forecaster's own chance of this, stated with the estimate: 10%; the middle value lies beyond the limit too.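

In this assay compound 4 gives < 100 nM, which is a limit and not a number. Its steps to compound 1, compound 2 and compound 3 therefore cannot be read. From the compounds shown here alone, whether 2-carboxyethyl gives a higher or lower number than the groups of those three compounds remains open.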